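Swapping an aryl group on a bromo-bearing fused core

The source may report more compounds than this note shows. Statements on the series, on what has been measured and on what is new or still open speak of the compounds shown alone.

compound 1, `Cc1ccc(-c2cn3nc(Cc4ccc(Cl)cc4)sc3n2)cc1`: > 250000 nM
compound 2, `Clc1ccc(Cc2nn3cc(-c4ccc(Cl)cc4Cl)nc3s2)cc1`: 247000 nM
compound 3, `Cc1ccc(-c2nc3sc(Cc4ccc(Cl)cc4)nn3c2Br)cc1`: > 250000 nM

In a functional assay on L1210 cells (Mus musculus) for cytotoxicity, with a stated time of 48 h (a lower number here means a stronger inhibitor, a higher number a weaker inhibitor), compound 1 gives only a limit of the assay, > 250000 nM. Compound 2 gives a measured number, 247000 nM. Compound 3 again gives only a limit, > 250000 nM. The change from compound 1 to compound 2 is 2,4-dichlorophenyl in place of 4-methylphenyl on an aromatic carbon; it made an at least 1.0-fold lower number from compound 1 to compound 2 (0.00 log units; that floor lies within the scatter). The two cores differ by bromo in place of hydrogen on an aromatic carbon, and the step that the two limits leave unreadable from compound 1 to compound 3 cannot be sized because both values sit at the limit of > 250000 nM in this assay, at which 2 of the 3 values shown sit.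

Compound 4, `Clc1ccc(Cc2nn3c(Br)c(-c4ccc(Cl)cc4Cl)nc3s2)cc1`, is not yet measured in this assay. It differs from compound 3 by 2,4-dichlorophenyl in place of 4-methylphenyl on an aromatic carbon, the same kind of change as from compound 1 to compound 2, though here the aromatic carbon is also next to the ring atom that bears a bromo group. Beside that earlier step, the expected step is a number no higher from compound 3 to compound 4 (the limit leaves the size open), resting on compound 2 with its value 247000 nM. Compound 4 is therefore estimated at 250000 nM, between 120000 nM and 600000 nM.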

Compound 4, half-maximal inhibitory concentration: 31000 nM
For compound 4 the middle estimate is 8.1-fold (0.91 log units) above the measured one; the measured number lies below the stated range.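

In this assay, placing 2,4-dichlorophenyl in place of 4-methylphenyl on the bromo-bearing core gives an at least 8.0-fold lower number from compound 3 to compound 4 (0.90 log units; beyond the scatter), and adding the bromo to the core of compound 2 gives an 8.0-fold lower number from compound 2 to compound 4 (0.90 log units; beyond the scatter). Set beside the same aryl change on the core without the bromo, the comparison reads: the same change on two cores in this assay, an at least 1.0-fold lower number (0.00 log units; that floor lies within the scatter) from compound 1 to compound 2 and an at least 8.0-fold lower number (0.90 log units; beyond the scatter) from compound 3 to compound 4; the limit leaves it open whether they differ Compound 1 stands only at a limit, > 250000 nM, so these data do not show whether the change does as much on the core without the bromo, and one clear drop does not make a rule for the series.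

The compounds shown leave open whether an amine or a carboxylic acid in place of the bromo would also lower the number. They also leave open whether a phenyl group carrying a single chlorine would do the same as 2,4-dichlorophenyl.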